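The compounds below may be only part of what the source reports. "The series", "measured", "known", "first", "only" and "open" are said of these compounds alone.

Working notes on the series, read in a functional assay on cells (Endothelial cell, Sus scrofa) for antiproliferative activity; on this read-out higher numbers stand for weaker inhibition and lower numbers for stronger inhibition. For the measured compounds named here, compound 1 `CCOC(=O)CNC(=O)O[C@@H]1CO[C@]2(COC(C)(C)O2)[C@@](O)(C2OC2CC(C)C)[C@@H]1OC` gives 343000 nM, the only single number available so far. Compound 2 `CO[C@@H]1[C@H](OC(=O)NC(=O)CCl)CO[C@]2(COC(C)(C)O2)[C@@]1(O)C1OC1CC(C)C` has two entries instead of one number, 124000 nM; 178000 nM (2 entries), so the comparison with compound 1 remains loose.

Compound 3 `CCOC(=O)NC(=O)O[C@@H]1CO[C@]2(COC(C)(C)O2)[C@@](O)(C2OC2CC(C)C)[C@@H]1OC` is still to be measured. Relative to compound 1, it has ethoxycarbonyl in place of (ethoxycarbonyl)methyl on an amide-type nitrogen, while the shared core stays the same.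

Going by the values given here, no measured step covers this change. The nearest guide is compound 2, which also has a carbonyl on the amide-type nitrogen and gives 124000 nM; 178000 nM (2 entries). On that single comparison, a modest move towards stronger inhibition is expected in this assay, and it may not clear the scatter. The expected size is a 1.7-fold lower number from compound 1 to compound 3 (0.23 log units; within the scatter). For compound 3 the estimated value is 200000 nM, with an expected range of 80000 nM to 450000 nM.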

Compound 3, half-maximal inhibitory concentration: 398000 nM
Compound 3: the middle estimate sits 2.0-fold (0.30 log units) below what was measured, within the range that was stated.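

In this assay, ethoxycarbonyl in place of (ethoxycarbonyl)methyl on an amide-type nitrogen gives a 1.2-fold higher number from compound 1 to compound 3 (0.06 log units; within the scatter). For the compounds shown here, this is the first step read at this nitrogen, and on it compound 3 cannot be told apart from compound 1, so carrying a carbonyl directly on the nitrogen, a feature compound 3 shares with compound 2, does not by itself separate compound 3 from compound 1 on this read-out. Repeat entries for one compound in this series also spread, which gives a step of this size little weight: the several entries of compound 2 in this assay, 124000 nM; 178000 nM (2 entries)

The compounds shown leave open whether any group on this nitrogen can move the number beyond the scatter, for example a carboxylic acid in place of the ethyl ester of compound 1, an amine, or a longer chain between the nitrogen and the ester. They also leave the place of compound 2 unsettled, since no step is listed for it and its entries of 124000 nM; 178000 nM (2 entries) give only a loose comparison with the other two compounds.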